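Bromo in place of chloro: working notes

The source may hold more compounds than are shown below. What is called first, only, known or untested is meant among the compounds shown, and "the series" means these compounds.

Values in a functional assay on MCF7 cells (Homo sapiens) for antiproliferative activity, read by sulforhodamine B assay, with a stated time of 72 h (on this read-out lower numbers stand for stronger inhibition and higher numbers for weaker inhibition), are these:
- Compound 1 `O=c1c(-c2csc3ccccc23)coc2ccccc12` gives > 10000 nM as a limit
- Compound 2 `O=C(/C=C/c1cc2ccccc2s1)c1cc(Cl)ccc1O` gives > 10000 nM as a limit

Compound 2 stands at the limit of > 10000 nM in this assay, at which 2 of the 2 values shown sit, and has no number of its own. Compound 3 `O=C(/C=C/c1cc2ccccc2s1)c1cc(Br)ccc1O` differs from it by bromo in place of chloro on an aromatic carbon, para to a hydroxy group, counted as bromo in place of chloro on an aromatic carbon in the structures. Within the data shown here, no measured step bears on this change. Compound 2 offers only the limit > 10000 nM as a starting point, so no shift beyond the usual scatter is expected in this assay in either direction. The estimated step that the limit leaves unreadable from compound 2 to compound 3 is expected to stay that small. Compound 3 is estimated at 14000 nM within an expected range of 6000 nM to 30000 nM with a limit reading also likely.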

Compound 3, half-maximal inhibitory concentration: > 10000 nM
Compound 3 was reported as a limit; the forecaster's own chance of this, stated with the estimate: 70%; the middle value does not contradict the limit.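

No step can be read from compound 2 to compound 3, since each gives only a limit: the limit of > 10000 nM in this assay, at which 3 of the 3 values shown sit.

The compounds shown leave open whether bromo and chloro differ at this place on the ring.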